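Where a Trifluoromethyl Group Enters Compound 1

This account rests on a few compounds, and the source may have more. Where it says the series, first, only, none or still open, it means among the compounds named here.

Compound 1 `C[C@@H](NC(=O)Nc1ccccc1F)c1ccccc1` gives 97% in an ADME assay on the whole organism with Oryza sativa as the target, tested at 0.1 uM (on this read-out higher numbers stand for a weaker effect at the one concentration tested and lower numbers for a stronger effect), and sits alongside compound 2 `C[C@@H](NC(=O)Nc1ccccc1Br)c1ccccc1`, which gives 99%, the two separated by a number 2 percentage points higher from compound 1 to compound 2 (within the scatter). Compound 3 `C[C@@H](NC(=O)Nc1cccc(C(F)(F)F)c1F)c1ccccc1` differs from compound 1 by trifluoromethyl in place of hydrogen on an aromatic carbon. Among the measured compounds shown here, no measured step introduces a trifluoromethyl group; the only step measured, bromo in place of fluoro on an aromatic carbon, stayed within the scatter, so no step beyond the scatter is expected here either. The expected step is no change at the digits printed from compound 1 to compound 3 (within the scatter). Compound 3 is therefore estimated at 97%, between 88% and 100%.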

Compound 3, a percentage reported as activity, at one concentration (the size of the read-out at that concentration, not a potency): 99%
Estimate against measurement, compound 3: 2 percentage points below; the range from low to high includes it.
By their numbers in this assay, from the lowest: compounds 1, 2 and 3 (each within the scatter of the next).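

In this assay, trifluoromethyl in place of hydrogen on this aromatic carbon, ortho to a fluoro group, brings a number 2 percentage points higher from compound 1 to compound 3 (within the scatter). This position therefore carries a group of 4 heavy atoms with no step beyond the scatter, which the swap of fluoro for bromo could not show. No available evidence bears on this result.

On these data alone, whether an amine or a carboxylic acid on this same aromatic carbon would move the number beyond the scatter stays open. So does the outcome of trifluoromethyl in a compound with bromo in place of fluoro.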